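A few compounds are considered here, and "the series" means these few. Any claim that something is new, unique, unknown or untested is made for them only; others in the source may bear on it.

Measured in a functional assay on brain (Rattus norvegicus, strain Wistar) for inhibition; on this read-out lower numbers stand for stronger inhibition and higher numbers for weaker inhibition:
- compound 1 `CCCCOc1ccc(-c2c(C)[nH]c(=O)n2C)cc1`: 5100 nM
- compound 2 `Cc1[nH]c(=O)n(C)c1-c1ccc(C2CCCCC2)cc1`: 10000 nM
- compound 3 `Cc1[nH]c(=O)n(C)c1-c1ccc(-c2ccccc2)cc1`: 6300 nM

Compound 3 gives 6300 nM, which does not separate it from compound 1 or compound 2, as all three values lie within the scatter of each other.

Still unmeasured is compound 4 `Cc1[nH]c(=O)n(C)c1-c1ccc(Oc2ccccc2)cc1`. The change is phenoxy in place of phenyl on an aromatic carbon.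

Three measured steps exchange the group at this place: a 1.2-fold higher number from compound 1 to compound 3 (0.09 log units; within the scatter), a 1.6-fold lower number from compound 2 to compound 3 (0.20 log units; within the scatter) and a 2.0-fold higher number from compound 1 to compound 2 (0.29 log units; within the scatter). None leaves the scatter, although butoxy, cyclohexyl and phenyl all occur among them. No step beyond the scatter is therefore expected in this assay, in either direction.

The expected step is a 1.1-fold lower number from compound 3 to compound 4 (0.06 log units; within the scatter). Compound 4 is estimated at 5500 nM, with an expected range of 2300 nM to 13000 nM.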

Compound 4, half-maximal inhibitory concentration: 8100 nM
Beside the measured number, compound 4's estimate is 1.5-fold (0.17 log units) below it; the range from low to high includes it.
By their numbers in this assay, from the lowest: compounds 1, 3, 4 and 2 (each within the scatter of the next).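

In this assay, phenoxy in place of phenyl does not separate the two groups (a 1.3-fold higher number from compound 3 to compound 4 (0.11 log units; within the scatter)), and phenoxy in place of cyclohexyl stays equally unresolved (a 1.2-fold lower number from compound 2 to compound 4 (0.09 log units; within the scatter)). Phenyl in place of butyl on the oxygen also stays within the scatter (a 1.6-fold higher number from compound 1 to compound 4 (0.20 log units; within the scatter)), so a fourth group, and the first aromatic ring carried on that oxygen, leaves the read-out flat at this position. No supporting data bear on why these values stay together. Going by these compounds, whether an amine or a carboxylic acid at this position would give a step beyond the scatter stays open.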